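Trimming a Side Chain: From Compound 2 to Compound 3

A few compounds are considered here, and "the series" means these few. Any claim that something is new, unique, unknown or untested is made for them only; others in the source may bear on it.

Among the measured compounds shown here, compound 1 `CC(C)(C)c1ccc(C(=O)N2CCC3(CC2)C(=O)N(CC(=O)N2CCC(CCO)CC2)CN3c2ccccc2)cc1` is the only compound here with a result: in an assay on HEK293 cells for displacement of a labelled ligand from NPC1-like intracellular cholesterol transporter 1 (Homo sapiens) (a higher number here means a weaker inhibitor, a lower number a stronger inhibitor), compound 1 gives 2600 nM. Compound 2 `CC(C)(C)OC(=O)NCCCCNC(=O)CN1CN(c2ccccc2)C2(CCN(C(=O)c3ccc(C(C)(C)C)cc3)CC2)C1=O` shares the core but carries a different tail, and in this assay compound 2 gives "not determined" (no result reported), so its standing cannot be placed on the scale. Compound 3 `CC(C)(C)OC(=O)NCCNC(=O)CN1CN(c2ccccc2)C2(CCN(C(=O)c3ccc(C(C)(C)C)cc3)CC2)C1=O` differs from compound 2 by (tert-butoxycarbonyl)amino in place of 2-((tert-butoxycarbonyl)amino)ethyl on a saturated chain carbon, two bonds along the chain from an amide-type nitrogen. For the measured compounds named here, with no measured step to lean on, a shift beyond the usual scatter in this assay is not expected in either direction. Compound 3 is therefore estimated at 3000 nM, with a range from 800 nM to 12000 nM.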

Compound 3, half-maximal inhibitory concentration: 10900 nM
Compound 3: the middle estimate sits 3.6-fold (0.56 log units) below what was measured, within the range that was stated.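

In this assay, putting (2-((tert-butoxycarbonyl)amino)ethyl)amino in place of 4-(2-hydroxyethyl)piperidin-1-yl on the carbonyl carbon gives a 4.2-fold higher number from compound 1 to compound 3 (0.62 log units; beyond the scatter), so this tail position does respond to change, and this replacement weakens binding. The step that trims the chain cannot be read, leaving the effect of chain length alone unknown. Nothing available explains the weakening. Still open, going by these compounds, is whether a free amine or a carboxylic acid in place of the (tert-butoxycarbonyl)amino would move the number in either direction.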